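Trading (2,6-difluorophenyl)carbamoyl for (ethoxycarbonyl)amino

The source may hold more compounds than are shown below. What is called first, only, known or untested is meant among the compounds shown, and "the series" means these compounds.

Compound 1 `Cc1cc(C(=O)Nc2c(F)cccc2F)nn1Cc1cc(Cl)ccc1OCc1ccccc1` — 3.7
Compound 2 `Cc1cc(NC(=O)C2CCCCC2)nn1Cc1cc(Cl)ccc1OCC(C)C` — > 3.7

Among the measured compounds shown here, in a physicochemical assay for lipophilicity, at pH 7.4 (on this read-out lower numbers stand for lower lipophilicity and higher numbers for higher lipophilicity), compound 1 gives 3.7, the only plain number in this small set. Compound 2 reaches only a limit of this assay, > 3.7, so its reading is a boundary rather than a number; (the limit of > 3.7 in this assay, at which 1 of the 2 values shown sits). Compound 3 `CCOC(=O)Nc1cc(C)n(Cc2cc(Cl)ccc2OCc2ccccc2)n1` is not yet measured. It differs from compound 1 in one place: (ethoxycarbonyl)amino in place of (2,6-difluorophenyl)carbamoyl on an aromatic carbon. For the measured compounds named here, no step between measured compounds is available, so nothing measured sets the size of this change. The step of a number 0.70 log units lower from compound 1 to compound 3 (beyond the scatter) is expected to lower the reading beyond the usual scatter. Compound 3 is estimated at 3, within 2.4 to 3.6.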

Compound 3, distribution coefficient: > 3.7
Compound 3: a limit, no number; the forecaster's own chance of this, stated with the estimate: 5%; at least 0.70 log units between middle value and limit.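

In this assay, the exchange on this aromatic carbon gives a number no lower from compound 1 to compound 3 (the limit leaves the size open). So (ethoxycarbonyl)amino, with 6 heavy atoms and no ring, does not bring the reading under that of compound 1, whose (2,6-difluorophenyl)carbamoyl has 11 heavy atoms and an aromatic ring. The size of the step cannot be read because the reading of compound 3 is a limit: the limit of > 3.7 in this assay, at which 2 of the 3 values shown sit.

As far as these compounds go, how far compound 3 lies from compound 1 stays open, as does whether an amine or a carboxylic acid on this same aromatic carbon would bring the reading down.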